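Swapping halogens on the aryl ketone of compound 1

The compounds below may be only part of what the source reports. "The series", "measured", "known", "first", "only" and "open" are said of these compounds alone.

Compound 1 `COc1cc(-c2cc(/C=C/C(=O)c3ccc(Cl)c(Cl)c3)[nH]n2)cc(OC)c1OC` was tested in a functional assay on SF-268 cells (Homo sapiens) for inhibition, read by sulforhodamine B assay, with a stated time of 48 h (a lower number here means a stronger inhibitor of growth, a higher number a weaker inhibitor of growth), and gave 13700 nM. Among the two compounds measured so far it holds the highest number, and its nearest neighbour is compound 2 `COc1ccc(-c2cc(/C=C/C(=O)c3cc(OC)c(OC)c(OC)c3)[nH]n2)cc1OC`, which in this assay gives 1680 nM, a gap that lies beyond the usual scatter. Compound 3 `COc1cc(-c2cc(/C=C/C(=O)c3ccc(F)c(F)c3)[nH]n2)cc(OC)c1OC` has not yet been measured. It differs from compound 1 in one place: 3,4-difluorophenyl in place of 3,4-dichlorophenyl on a carbonyl carbon. Among the measured compounds shown here, no measured pair in this set shows what such a halogen swap does on this core, so the expected step rests on the change itself rather than on any recorded step. The step from compound 1 to compound 3 is expected to be small, a 1.3-fold higher number from compound 1 to compound 3 (0.12 log units; within the scatter), with no confident direction beyond the scatter. Compound 3 is therefore estimated at 18000 nM in this assay, within a range from 5000 nM to 60000 nM.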

Compound 3, concentration for 50% growth inhibition: 3150 nM
For compound 3 the middle estimate is 5.7-fold (0.76 log units) above the measured one, outside the stated range (below it).
By their numbers in this assay, from the lowest: compounds 2 and 3 (each within the scatter of the next); then compound 1.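

In this assay, among the compounds shown here, the exchange of 3,4-dichlorophenyl for 3,4-difluorophenyl on the carbonyl carbon gives a 4.3-fold lower number from compound 1 to compound 3 (0.64 log units; beyond the scatter) and so provides the first reading of this position on the shared core. It shows that growth inhibition here responds to the identity of the halogen, even though the two groups have the same number of heavy atoms and the same ring. Nothing available accounts for the size of this step.

For the compounds shown here, with only two halogenated groups compared, it remains open whether the numbers would follow the halogen in a consistent order, as a 3,4-dibromophenyl group or an unsubstituted phenyl ring could show. It is also unknown whether a single fluorine would be enough, or whether the same exchange would give a similar step with a different aryl group on the far side of the core.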